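The source may report more compounds than this note shows. Statements on the series, on what has been measured and on what is new or still open speak of the compounds shown alone.

Working notes on the aminothiazole series.

Of the compounds shown here, three sharing the same core have been measured. Compound 3 `CCCN(CCCc1ccc(O)c(OC)c1)C1CCc2nc(N)sc2C1` carries a 4-hydroxy-3-methoxyphenyl on a three-carbon chain; in an assay on HEK293 cells for displacement of a labelled ligand from D(3) dopamine receptor (Rattus norvegicus), with a stated time of 1 h (a lower number here means a stronger inhibitor, a higher number a weaker inhibitor), compound 3 gives 15.8 nM. Compound 1 `CCCN(CCCc1ccc(O)c(O)c1)C1CCc2nc(N)sc2C1` is its demethylated counterpart, and in this assay compound 1 gives 11.9 nM. The difference between them, (hydrogen in place of methyl on an oxygen on an aromatic ring), produced a 1.3-fold lower number from compound 3 to compound 1 (0.12 log units; within the scatter), so the two numbers are not distinguished here.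

Compound 2 `CCCN(CCCCCc1ccc(O)c(OC)c1)[C@H]1CCc2nc(N)sc2C1` carries the methoxy-bearing aryl on a longer chain with a defined configuration at the core; in this assay compound 2 gives 1.57 nM, the lowest of the three, and its gaps to compound 1 and compound 3 both lie beyond the scatter. The difference between the cores of compound 2 and compound 3 is not broken down here.

Compound 4 `CCCN(CCCCCc1ccc(O)c(O)c1)[C@H]1CCc2nc(N)sc2C1` is not yet measured. It differs from compound 2 by hydrogen in place of methyl on an oxygen on an aromatic ring, the same change that was made from compound 3 to compound 1. That step stayed within the scatter, so the step from compound 2 to compound 4 is expected to be about a 1.2-fold lower number from compound 2 to compound 4 (0.08 log units; within the scatter), resting on a 1.3-fold lower number from compound 3 to compound 1 (0.12 log units; within the scatter). Compound 4 is therefore estimated at 1.3 nM, between 0.6 nM and 3 nM.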

Compound 4, inhibition constant: 1.42 nM
For compound 4 the middle estimate is 1.1-fold (0.04 log units) below the measured one; measured number inside the range.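

In this assay the change from methoxy to hydroxy on the aromatic ring gives a 1.1-fold lower number from compound 2 to compound 4 (0.04 log units; within the scatter), so the two numbers are not distinguished. Set beside the earlier pair, the change reads the same on both cores: the same change on two cores in this assay, a 1.3-fold lower number (0.12 log units; within the scatter) from compound 3 to compound 1 and a 1.1-fold lower number (0.04 log units; within the scatter) from compound 2 to compound 4, 1.2-fold (0.08 log units) apart, within the scatter of two such steps. This shows that, in these two pairs, hydrogen in place of methyl on this oxygen leaves the number within the scatter and that the step carried over from one core to the other, but it does not show that the change would be as quiet on any further core, and both pairs go from 4-hydroxy-3-methoxyphenyl to 3,4-dihydroxyphenyl, so nothing follows for other aryl groups.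

Still open, from the compounds shown here alone, is whether a larger group on this oxygen, such as ethyl, or an amine in place of the hydroxy, would also leave the number unchanged. Also open are the separate contributions of chain length and configuration at the core, which change together in the compounds shown.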